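Methyl on the ring amide nitrogen of compound 3

The source may report more compounds than this note shows. Statements on the series, on what has been measured and on what is new or still open speak of the compounds shown alone.

In a functional assay on the whole organism for agonist activity, with Mus musculus as the target (on this read-out higher numbers stand for an effect only at larger amounts of compound and lower numbers for an effect already at smaller amounts), the measured compounds read as follows:
- compound 1 `CC1CCC(=O)N1CC#CCn1ccnc1` gives > 100 mg/kg
- compound 2 `CCOC(=O)N(C)CC#CCN1CCCC1` gives > 100 mg/kg
- compound 3 `Cc1cncn1CC#CCN1CCNC1=O` gives > 100 mg/kg

Compound 3 stands at > 100 mg/kg in this assay and this is a limit, not a number. Compound 1 and compound 2 likewise give only limits. The series therefore has no graded value yet, and the whole read-out rests on the limit of > 100 mg/kg in this assay, at which 3 of the 3 values shown sit, as its single reference point.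

Compound 4 `Cc1cncn1CC#CCN1CCN(C)C1=O` differs from compound 3 by one change methyl in place of hydrogen on an amide-type nitrogen in a ring with methyl in place of hydrogen on an amide-type nitrogen in a ring. Within the data shown here, no two measured compounds differ in one place, so the size of this change has no measured precedent. No shift beyond the usual scatter is expected in this assay in either direction, and another limit is the likeliest report. The expected step that the limit leaves unreadable from compound 3 to compound 4 is an estimate only. The estimated value for compound 4 is 130 mg/kg with an expected range from 50 mg/kg to 300 mg/kg on this read-out.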

Compound 4, dose for half-maximal effect: 14 mg/kg
Compound 4: middle estimate off by 9.3-fold (0.97 log units), on the high side; measured number outside the range, below it.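

Methyl in place of hydrogen on an amide-type nitrogen in a ring gives, in this assay, an at least 7.1-fold lower number from compound 3 to compound 4 (0.85 log units; beyond the scatter), so this nitrogen is a position where a single added carbon changes the read-out. Among these compounds, in this pair the amide hydrogen is not required for an effect in the whole organism, and replacing it is the only difference between a compound without a graded value and one with a graded value. Compound 4 is so far the only graded value in the series, and everything else rests on one reference point: the limit of > 100 mg/kg in this assay, at which 3 of the 4 values shown sit.

Going by these compounds, whether ethyl, a longer chain or acetyl on the same nitrogen keeps, improves or loses the effect stays open. Also open, on these data alone, is whether the step carries over to a different core, as it rests on this single pair.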